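The source may hold more compounds than are shown below. What is called first, only, known or untested is meant among the compounds shown, and "the series" means these compounds.

Compound 1, `COc1ccccc1COc1ccccc1/C=C/C=C1\SC(=S)NC1=O`, heads the small group of three measured compounds in a functional assay on DLD-1 cells (Homo sapiens), read by microscopy and crystal violet staining, with a stated time of 20 h, tested at 10 ug/mL (a higher number here means more inhibition at the concentration tested (going by the name of the read-out), a lower number less inhibition), where compound 1 gives 98%. Compound 3, `O=C1NC(=S)S/C1=C\c1cc(Br)ccc1OCc1ccccc1Br`, comes closest: in this assay compound 3 gives 95%, a reading within the scatter of that of compound 1, so no order between the two can be claimed. Compound 2, `O=C1NC(=O)/C(=C/C=C/c2ccccc2OCc2ccccc2Br)S1`, stands furthest away; in this assay compound 2 gives 50%, well beyond the scatter below compound 1.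

The account now turns to compound 4, `O=C1NC(=S)S/C1=C\C=C\c1ccccc1OCc1ccccc1`, which has not yet been measured. Compound 4 is reached from compound 1 by a single change, (hydrogen in place of methoxy on an aromatic carbon), on an aromatic carbon of a six-membered aromatic ring of carbon only, ortho to a large group. Going by the values given here, nothing else in the two structures differs, and no measured pair shows this same change, so the size of its effect has to be guessed from the spread of the three numbers at hand.

Since compound 1 already sits near the top of what this assay can report, the expected step of a number 10 percentage points lower from compound 1 to compound 4 (within the scatter) is a small decrease, possibly not beyond the scatter. Compound 4 is therefore estimated to give 88% in this assay, expected to fall between 60% and 100%.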

Compound 4, a percentage reported as inhibition, at one concentration (the size of the read-out at that concentration, not a potency): 65%
Estimate against measurement, compound 4: 23 percentage points above; the range from low to high includes it.
By their numbers in this assay, from the lowest: compound 2; then compound 4; then compounds 3 and 1 (each within the scatter of the next).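

In this assay, the methoxy on an aromatic carbon, ortho to a large group, proves not to be interchangeable with hydrogen: this single change, which turns 2-methoxyphenyl into phenyl, gives a number 33 percentage points lower from compound 1 to compound 4 (beyond the scatter). This is the only step shown between two compounds that differ in one place, so it gives the first direct reading of this position and shows that the reading at the tested concentration depends on what the ring carries there, although this one pair cannot support a wider pattern. No accompanying measurement bears on the reason for the drop.

Still open, from the compounds shown here alone, is whether the higher reading is particular to methoxy or would also be seen with another group on that aromatic carbon, such as hydroxy, ethoxy, chlorine or an amine. Going by these compounds, it is also open whether the same change would produce a step of similar size on a different core, such as the core of compound 2.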